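A few compounds are considered here, and "the series" means these few. Any claim that something is new, unique, unknown or untested is made for them only; others in the source may bear on it.

In an in vitro functional assay on cells for agonist activity at Bombesin receptor subtype-3 (Homo sapiens), read by luminescence and calcium flux (on this read-out lower numbers stand for an effect already at smaller amounts and higher numbers for an effect only at larger amounts of compound), compound 1 `O=C(O)c1ccccc1-c1ccc(CCc2ncc(Cc3ccccc3F)[nH]2)cc1` gives 177 nM. Compound 2 `N#Cc1cccc(Cc2cnc(CCc3ccc(-c4ccccc4C(=O)O)cc3)[nH]2)c1` gives 812 nM in this assay, and compound 3 `O=C(O)c1ccccc1-c1ccc(CCc2ncc(CCC3CCCCC3)[nH]2)cc1` gives 642 nM. Compound 3 thus stands second highest of the three numbers: its value lies within the scatter of that of compound 2, and beyond the scatter above that of compound 1. Compound 4 `CC(C)(C)CCc1cnc(CCc2ccc(-c3ccccc3C(=O)O)cc2)[nH]1` has not yet been measured in this assay. The change from compound 3 to compound 4 is tert-butyl in place of cyclohexyl on a saturated chain carbon, two bonds along the chain from an aromatic carbon. Among the measured compounds shown here, two measured steps touch this part of the molecule. The step of a 3.6-fold higher number from compound 1 to compound 3 (0.56 log units; beyond the scatter) was beyond the scatter, while the step of a 1.3-fold lower number from compound 2 to compound 3 (0.10 log units; within the scatter) stayed within it, so exchanging one tail group for another at this place has so far moved the number modestly at most. For the measured compounds named here, no measured step trades a ring for an open chain here. Compound 4 is therefore expected to give about 900 nM, within a range from 300 nM to 2700 nM. The expected step of a 1.4-fold higher number from compound 3 to compound 4 (0.15 log units; within the scatter) is thus small and may not exceed the scatter.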

Compound 4, half-maximal effective concentration: 39 nM
Compound 4: middle estimate off by 23-fold (1.36 log units), on the high side; the measured number lies below the stated range.
By their numbers in this assay, from the lowest: compound 4; then compound 1; then compounds 3 and 2 (each within the scatter of the next).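

Trading the ring for an open chain at this place is not just another tail exchange: a 16-fold lower number from compound 3 to compound 4 (1.22 log units; beyond the scatter) is large, whereas the earlier exchanges among compounds 1, 2 and 3 were modest at most. Compound 4 also sets the lowest number of the four in this assay, with a 21-fold lower number from compound 2 to compound 4 (1.32 log units; beyond the scatter) and a 4.5-fold lower number from compound 1 to compound 4 (0.66 log units; beyond the scatter), so the 2-fluorophenyl tail of compound 1, until now the best of the tails, is surpassed by the neopentyl tail, and a tail without a ring can do better than all three ring-bearing ones. No measurement at hand explains this gain. 

The compounds shown cannot separate the loss of the ring from the branching of the chain, which an unbranched n-pentyl tail would address. From the compounds shown here alone, whether this place tolerates other groups on the chain, such as an amine or a hydroxyl, also remains open.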